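Notes on a hydroxy to methylsulfanyl exchange

A few compounds are considered here, and "the series" means these few. Any claim that something is new, unique, unknown or untested is made for them only; others in the source may bear on it.

Measured so far:
compound 1 `C=CCn1ncc2c(C)nc(CC)n2c1=O` — assay limit > 48000 nM
compound 2 `CCCCCCCCCCCCCCCCCc1ncc2cnnc(S)n12` — assay limit > 48000 nM
compound 3 `Cc1nc(C(C)C)n2c(O)nnc(-c3ccccc3)c12` — assay limit > 48000 nM

In a functional assay for inhibition, with Homo sapiens as the target (on this read-out higher numbers stand for weaker inhibition and lower numbers for stronger inhibition), none of the three measured compounds returns a number. For compound 1 the read-out is only the assay limit > 48000 nM. For compound 2 the read-out is likewise only the limit > 48000 nM. For compound 3 the read-out is again only the limit > 48000 nM. Among the measured compounds shown here, compound 3 therefore cannot be placed against the others: it has a limit, and the two further values shown are limits as well, so no step between measured compounds can be drawn. All three sit at the limit of > 48000 nM in this assay, at which 3 of the 3 values shown sit.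

Compound 4 `CSc1nnc(-c2ccccc2)c2c(C)nc(C(C)C)n12` is not yet measured. It differs from compound 3 by methylsulfanyl in place of hydroxy on an aromatic carbon. For the measured compounds named here, no measured pair here separates hydroxy from methylsulfanyl at this position, and the only fact on this core is the limit of compound 3 in this assay. The step expected in this assay is an at least 1.0-fold lower number from compound 3 to compound 4 (0.02 log units; that floor lies within the scatter), with no measured basis for movement in either direction beyond the scatter. For compound 4 the estimate in this assay is 45000 nM, within 10000 nM to 150000 nM, and the read-out is expected most likely to come back again as a limit rather than a number.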

Compound 4, half-maximal inhibitory concentration: > 48000 nM
Compound 4 ended at the assay's limit; the forecaster's own chance of this, stated with the estimate: 70%; at least 1.0-fold (0.02 log units) between middle value and limit.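

In this assay compound 3 and compound 4 both end at the assay limit, so no step can be read for methylsulfanyl in place of hydroxy on an aromatic carbon: the limit of > 48000 nM in this assay, at which 4 of the 4 values shown sit. The compounds shown leave open whether any change on the shared core yields a measurable number in this assay at all.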